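A Methoxy in Place of a Methyl

A few compounds are considered here, and "the series" means these few. Any claim that something is new, unique, unknown or untested is made for them only; others in the source may bear on it.

In a functional assay on NCI-H226 cells (Homo sapiens) for inhibition, read by MTT assay, with a stated time of 48 h, tested at 10 uM (a lower number here means less inhibition, a higher number more inhibition at the concentration tested (going by the name of the read-out)), compound 1 `COc1cc(NC(=O)Nc2cc(Nc3ccc(C)c(C)c3)ncn2)cc(OC)c1` gives 45.3%. Among the two numbers shown this is the lower one: compound 2 `COc1ccc(OC)c(Nc2cc(NC(=O)Nc3c(Cl)cccc3Cl)ncn2)c1` gives 81.7% in this assay, a reading that sits beyond the scatter above compound 1, although the two compounds differ in more than one place and no single step connects them. Compound 3 `COc1cc(NC(=O)Nc2cc(Nc3ccc(OC)c(C)c3)ncn2)cc(OC)c1` has not yet been measured in this assay. It differs from compound 1 as follows: methoxy in place of methyl on an aromatic carbon. Going by the values given here, no measured pair in this set shows what such a change does in this assay, so the data give no direction for it. The step of a number 2.7 percentage points higher from compound 1 to compound 3 (within the scatter) is therefore estimated to stay within the usual scatter, in neither direction. Compound 3 is expected to give about 48% in this assay, with a range from 30% to 66%.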

Compound 3, a percentage reported as inhibition, at one concentration (the size of the read-out at that concentration, not a potency): 39.7%
Beside the measured number, compound 3's estimate is 8.3 percentage points above it; low and high end bracket the measured number.
By their numbers in this assay, from the lowest: compounds 3 and 1 (each within the scatter of the next); then compound 2.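

Going by these compounds alone, this is the first measured pair for this change. On the 3,4-dimethylphenyl group of compound 1, at the place para to a large group and ortho to a methyl group, methoxy in place of methyl gives in this assay a step of a number 5.6 percentage points lower from compound 1 to compound 3 (within the scatter). The 4-methoxy-3-methylphenyl group of compound 3 thus brings one more hydrogen-bond acceptor by the count, and the two readings still stand within the scatter of each other. The data available here offer no explanation for this result.

As far as these compounds go, whether an ethoxy group, a hydroxyl or an amine at this place would give a reading beyond the scatter remains open. Also open, from the compounds shown here alone, is whether methoxy in place of methyl would give a similar step on a compound that differs elsewhere from compound 1.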